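Cyclohexyloxy for dipropylamino: expecting a small step

A few compounds are considered here, and "the series" means these few. Any claim that something is new, unique, unknown or untested is made for them only; others in the source may bear on it.

Measured compounds:
- compound 1 `CCCCN(C)c1nc(C(C)(C)C)ccc1CNC(=O)C(C)c1ccc(NS(C)(=O)=O)c(F)c1`: 1.2 nM
- compound 2 `CCCN(CCC)c1nc(C(C)(C)C)ccc1CNC(=O)C(C)c1ccc(NS(C)(=O)=O)c(F)c1`: 2.5 nM
- compound 3 `CC(C(=O)NCc1ccc(C(C)(C)C)nc1OC1CCCC1)c1ccc(NS(C)(=O)=O)c(F)c1`: 1.5 nM

All three compounds were tested in an assay on cells for antagonist activity at transient receptor potential cation channel subfamily V member 1 (Homo sapiens), read by FLIPR and calcium flux, with a stated time of 6 min; on this read-out higher numbers stand for weaker inhibition and lower numbers for stronger inhibition. Compound 2 gives 2.5 nM, the highest of the three numbers: its step to compound 3 is a 1.7-fold lower number from compound 2 to compound 3 (0.22 log units; within the scatter), within the scatter, while the step from compound 1 to compound 2 is a 2.1-fold higher number from compound 1 to compound 2 (0.32 log units; beyond the scatter), beyond the scatter. Compound 1 and compound 3 differ by a 1.3-fold higher number from compound 1 to compound 3 (0.10 log units; within the scatter), within the scatter.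

The unmeasured compound 4 `CC(C(=O)NCc1ccc(C(C)(C)C)nc1OC1CCCCC1)c1ccc(NS(C)(=O)=O)c(F)c1` comes from compound 2 by one change: cyclohexyloxy in place of dipropylamino on an aromatic carbon

Among the compounds with values here, the step that bears most directly on this change is the one from compound 2 to compound 3, a 1.7-fold lower number from compound 2 to compound 3 (0.22 log units; within the scatter), where a cyclopentyloxy group took the place of the same dipropylamino group at the same aromatic carbon and the number stayed within the scatter. The cyclohexyloxy group in compound 4 differs from cyclopentyloxy only by one ring carbon, so a step of similar size is expected in this assay, leaning toward a slightly lower number, but likely within the scatter.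

Compound 4 is therefore expected to give about 1.8 nM, with a range from 0.7 nM to 4.5 nM. This estimate means a step of a 1.4-fold lower number from compound 2 to compound 4 (0.14 log units; within the scatter).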

Compound 4, inhibition constant: 2.5 nM
The estimate for compound 4 lay 1.4-fold (0.14 log units) below the measured number; low and high end bracket the measured number.
By their numbers in this assay, from the lowest: compounds 1, 3, 2 and 4 (each within the scatter of the next, the first and the last beyond it).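

In this assay, cyclohexyloxy on this aromatic carbon next to the ring nitrogen gives no change at the digits printed from compound 2 to compound 4 (within the scatter), so this ring-bearing ether matches the open-chain dipropylamino group, which has the same number of heavy atoms. Adding one carbon to the ring on the oxygen gives a 1.7-fold higher number from compound 3 to compound 4 (0.22 log units; within the scatter), so the cyclopentyl and cyclohexyl ethers cannot be told apart on this read-out. The step that stands out is a 2.1-fold higher number from compound 1 to compound 4 (0.32 log units; beyond the scatter), which is beyond the scatter and modest, so compound 1 is now separated from both compound 2 and compound 4, although compound 3 remains within the scatter of compound 1.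

All four groups tested at this carbon are fairly large and rich in carbon, which leaves open whether a much smaller methoxy group, or a ring containing nitrogen such as piperidin-1-yl, would keep the numbers in this narrow range. Nothing given here explains why these different groups give such similar numbers.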